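Removing a Methyl from the Bromoacyl Chain on Two Cores

A few compounds are considered here, and "the series" means these few. Any claim that something is new, unique, unknown or untested is made for them only; others in the source may bear on it.

Compound 1 `Cc1c(NC(=O)C(C)Br)cccc1C(=O)NC(N)=O` and compound 3 `Cc1c(NC(=O)CBr)cccc1C(=O)NC(N)=O` share one core and differ only by hydrogen in place of methyl on a saturated chain carbon bound to a bromine atom and a carbonyl carbon. In a functional assay on CCRF-CEM cells (Homo sapiens) for antiproliferative activity, read by trypan blue exclusion, with a stated time of 72 h (a higher number here means a weaker inhibitor, a lower number a stronger inhibitor), compound 1 gives 480 nM, while compound 3 gives 1710 nM; this amounts to a 3.6-fold higher number from compound 1 to compound 3 (0.55 log units; beyond the scatter). Compound 2 `Cc1ccc(C(=O)NC(N)=O)cc1NC(=O)C(C)Br` is built from the same atoms as compound 1 joined differently, and the difference between the two cores is not broken down here. In this assay compound 2 gives 3360 nM. Compound 4 `Cc1ccc(C(=O)NC(N)=O)cc1NC(=O)CBr` has not yet been measured; it differs from compound 2 by hydrogen in place of methyl on a saturated chain carbon bound to a bromine atom and a carbonyl carbon, the same change at the same place. A step of similar size is expected, a 3.3-fold higher number from compound 2 to compound 4 (0.52 log units; beyond the scatter), because the earlier pair showed a 3.6-fold higher number from compound 1 to compound 3 (0.55 log units; beyond the scatter) and nothing else is known about this change. Compound 4 is therefore estimated at 11000 nM in this assay, most likely between 4500 nM and 28000 nM.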

Compound 4, half-maximal inhibitory concentration: 4280 nM
Compound 4: the middle estimate sits 2.6-fold (0.41 log units) above what was measured; the measured number lies below the stated range.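

In this assay, the change from 1-bromoethyl to bromomethyl gives a 1.3-fold higher number from compound 2 to compound 4 (0.11 log units; within the scatter), so on this core, removing the methyl leaves a step that cannot be told apart from the scatter. The same change therefore does not carry over at the same size from one core to the other: the same change on two cores in this assay, a 3.6-fold higher number (0.55 log units; beyond the scatter) from compound 1 to compound 3 and a 1.3-fold higher number (0.11 log units; within the scatter) from compound 2 to compound 4, 2.8-fold (0.45 log units) apart, beyond the scatter of two such steps

This shows that, for these two pairs, the size of the step depends on the core, but two pairs give no rule for other cores and do not show why the cores differ. The compounds shown leave open how the change would behave on further cores. They also leave open whether a longer chain in place of 1-bromoethyl, or a chlorine atom in place of the bromine atom, would follow the same course on both cores.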